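Fluoro versus trifluoromethyl on the aryl of a shared core

A few compounds are considered here, and "the series" means these few. Any claim that something is new, unique, unknown or untested is made for them only; others in the source may bear on it.

In a functional assay on HT-29 cells (Homo sapiens) for antiproliferative activity, read by sulforhodamine B assay, with a stated time of 72 h (a lower number here means a stronger inhibitor, a higher number a weaker inhibitor), compound 1 `FC(F)(F)c1ccccc1NC(=S)N/N=C/c1ccc2ccccc2n1` gives 18100 nM. Compound 2 `Fc1ccccc1NC(=S)N/N=C/c1ccc2ccccc2n1` gives only a limit of the assay, > 100000 nM. Compound 3 `Fc1ccc(NC(=S)N/N=C/c2ccc3ccccc3n2)cc1` gives 28500 nM in this assay. Compound 2 and compound 3 differ by 4-fluorophenyl in place of 2-fluorophenyl on an amide-type nitrogen, and this brought an at least 3.5-fold lower number from compound 2 to compound 3 (0.54 log units; beyond the scatter). Compound 2 and compound 1 differ by trifluoromethyl in place of fluoro on an aromatic carbon, which brought an at least 5.5-fold lower number from compound 2 to compound 1 (0.74 log units; beyond the scatter); the full size of that step is open because of the limit of > 100000 nM in this assay, at which 1 of the 3 values shown sits. Compound 4 `FC(F)(F)c1ccc(NC(=S)N/N=C/c2ccc3ccccc3n2)cc1` carries the same kind of change on compound 3: trifluoromethyl in place of fluoro on an aromatic carbon, here para to a large group rather than ortho to a large group. The earlier step rests on a limit at compound 2 and on a different place, so a smaller gain is expected. The step from compound 3 to compound 4 is expected to be a 2.4-fold lower number from compound 3 to compound 4 (0.38 log units; beyond the scatter). Compound 4 is expected to give about 12000 nM, between 4000 nM and 40000 nM.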

Compound 4, half-maximal inhibitory concentration: 63900 nM
The estimate for compound 4 lay 5.3-fold (0.73 log units) below the measured number; measured number above the stated range.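

In this assay, trifluoromethyl in place of fluoro gives a 2.2-fold higher number from compound 3 to compound 4 (0.35 log units; beyond the scatter), so the gain seen with this change in the other pair does not transfer, and the direction of the step depends on the core: the same change on two cores in this assay, an at least 5.5-fold lower number (0.74 log units; beyond the scatter) from compound 2 to compound 1 and a 2.2-fold higher number (0.35 log units; beyond the scatter) from compound 3 to compound 4, at least 12-fold (1.09 log units) apart, beyond the scatter of two such steps

Compound 2 is read only as a limit, > 100000 nM. Two pairs do not show what sets the direction, and they give no general rule for this change across the series.

Going by these compounds, it remains open how other groups on the aromatic carbon para to a large group, such as chloro, methoxy or an amine, would compare with fluoro and trifluoromethyl. On these data alone, it is also open whether a single such group would behave alike on both cores.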